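The compounds below may be only part of what the source reports. "The series", "measured", "known", "first", "only" and "open" are said of these compounds alone.

Compound 1 `COc1cc2c(cc1OC)CN(CCn1cc(COc3ccc4ccccc4c3)nn1)CC2`: in an ADME assay on K562 cells (Homo sapiens) for cytotoxicity, read by MTT assay, with a stated time of 48 h (a lower number here means a stronger inhibitor, a higher number a weaker inhibitor), compound 1 gives > 100000 nM, which is a limit of the assay and not a number.
Compound 2 `COc1cc2c(cc1OC)CN(CCn1cc(COc3ccc([N+](=O)[O-])cc3)nn1)CC2`: in this assay compound 2 gives > 100000 nM, again a limit of the assay rather than a number.

Compound 2 thus stands at the upper edge of what this assay reports, where both measured compounds sit (the limit of > 100000 nM in this assay, at which 2 of the 2 values shown sit). Within the data shown here, the only measured step, a step that the two limits leave unreadable from compound 1 to compound 2, changes the group on the oxygen on the saturated carbon, the same position as the step now followed, but its two limits leave its size unreadable, so it gives no direction.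

Compound 3 `COc1cc2c(cc1OC)CN(CCn1cc(COc3ccc(C)c(C)c3)nn1)CC2` has not been measured. It differs from compound 2 by 3,4-dimethylphenyl in place of 4-nitrophenyl on an oxygen on a saturated carbon. With no readable step to lean on, compound 3 is expected to stay at the limit, an estimated step that the limit leaves unreadable from compound 2 to compound 3 that is none beyond the scatter. Compound 3 is therefore estimated at 150000 nM in this assay, within 40000 nM to 600000 nM, most likely reported only as a limit.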

Compound 3, half-maximal inhibitory concentration: > 100000 nM
Compound 3: only a limit was reported; the forecaster's own chance of this, stated with the estimate: 85%; the middle value is on the limit's open side.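

Compound 3 gives only a limit of the assay, as do compound 1 and compound 2, so no step among these three compounds can be read. Whether any group at this place gives a true number in this assay stays open with the compounds shown.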